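Indole for Phenyl in a Weak Histone Deacetylase 8 Series

A few compounds are considered here, and "the series" means these few. Any claim that something is new, unique, unknown or untested is made for them only; others in the source may bear on it.

Compound 3 `CC(=O)N1C(NCc2ccc(C(=O)Nc3ccccc3N)cc2)=NC(=O)C1Cc1ccccc1` is a weak inhibitor in an assay for inhibition of histone deacetylase 8 (Homo sapiens), read by fluorescence, with stated times of 15 min and 60 min (a lower number here means a stronger inhibitor, a higher number a weaker inhibitor), where compound 3 gives 22700 nM. Compound 2 `CC(C)(C)OC(=O)N1C(NCc2ccc(C(=O)Nc3ccccc3N)cc2)=NC(=O)C1Cc1c[nH]c2ccccc12` gives 27200 nM in this assay, and the two numbers lie within the scatter of each other, so neither stands above the other. For compound 1 `Nc1ccccc1NC(=O)c1ccc(CNC2=NC(=O)C(Cc3c[nH]c4ccccc34)N2)cc1` this assay reports only a limit, > 20000 nM. The step that the limit leaves unreadable from compound 1 to compound 2 is therefore not readable (the limit of > 20000 nM in this assay, at which 1 of the 3 values shown sits). Compound 4 `CC(=O)N1C(NCc2ccc(C(=O)Nc3ccccc3N)cc2)=NC(=O)C1Cc1c[nH]c2ccccc12` differs from compound 3 in one place: 1H-indol-3-yl in place of phenyl on a saturated chain carbon bound to a saturated ring carbon. For the measured compounds named here, no measured step follows this same change, since compound 2 and compound 3 differ in two places at once. The expected step for compound 4 is thus none beyond the scatter, a 1.0-fold lower number from compound 3 to compound 4 (0.01 log units; within the scatter). Compound 4 is estimated at 22000 nM, within a range from 9000 nM to 55000 nM.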

Compound 4, half-maximal inhibitory concentration: 24300 nM
Beside the measured number, compound 4's estimate is 1.1-fold (0.04 log units) below it; low and high end bracket the measured number.
By their numbers in this assay, from the lowest: compounds 3, 4 and 2 (each within the scatter of the next).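

Put through this assay, the change from benzyl to (1H-indol-3-yl)methyl on this saturated ring carbon gives a 1.1-fold higher number from compound 3 to compound 4 (0.03 log units; within the scatter), so the two aromatic groups cannot be told apart here, even with the added ring and hydrogen-bond donor. Methyl in place of tert-butoxy on the carbonyl carbon gives a 1.1-fold lower number from compound 2 to compound 4 (0.05 log units; within the scatter), so that change cannot be told apart either. Compound 1 has only a limit, not a number, so its step to compound 4 cannot be read: the limit of > 20000 nM in this assay, at which 1 of the 4 values shown sits.

Going by these compounds, whether a carboxylic acid, an amine or a longer chain at this position would shift the number beyond the scatter stays open.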